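A few compounds are considered here, and "the series" means these few. Any claim that something is new, unique, unknown or untested is made for them only; others in the source may bear on it.

In a functional assay on Malme-3M cells (Homo sapiens) for inhibition, read by sulforhodamine B assay, with a stated time of 48 h, tested at 0.1 uM (a lower number here means a stronger effect, a higher number a weaker effect of the compound at the concentration tested), compound 3 `COc1cc(Cl)cc(-c2nn(-c3cccc(NC(=O)Nc4ccc(Cl)c(Cl)c4)c3)cc2-c2ccncc2)c1` gives 50%, the lowest of the three numbers. Compound 1 `O=C(Nc1cccc(-n2cc(-c3ccncc3)c(-c3cc(O)cc(Cl)c3)n2)c1)Nc1ccc(Cl)c(Cl)c1` gives 84% and compound 2 `COc1cc(Cl)cc(-c2nn(-c3cccc(NC(=O)Nc4ccc(Cl)c(C(F)(F)F)c4)c3)cc2-c2ccncc2)c1` gives 79%; the steps of a number 34 percentage points lower from compound 1 to compound 3 (beyond the scatter) and a number 29 percentage points lower from compound 2 to compound 3 (beyond the scatter) are both beyond the scatter, so compound 3 is the strongest of the three. Compound 4 `COc1cc(Cl)cc(-c2nn(-c3cccc(NC(=O)c4cccc(C(F)(F)F)c4)c3)cc2-c2ccncc2)c1` differs from compound 3 by 3-(trifluoromethyl)phenyl in place of (3,4-dichlorophenyl)amino on a carbonyl carbon. Among the compounds with values here, no measured step removes the (3,4-dichlorophenyl)amino group from the carbonyl carbon, so the change has no direct precedent. Within the data shown here, the only step involving trifluoromethyl is a number 29 percentage points lower from compound 2 to compound 3 (beyond the scatter), where the trifluoromethyl compound gave the weaker number. A step back toward weaker effect is therefore expected, a number 25 percentage points higher from compound 3 to compound 4 (beyond the scatter). Compound 4 is estimated at 75%, with a range of 55% to 95%.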

Compound 4, a percentage reported as activity, at one concentration (the size of the read-out at that concentration, not a potency): 90%
For compound 4 the middle estimate is 15 percentage points below the measured one, within the range that was stated.
By their numbers in this assay, from the lowest: compound 3; then compounds 2, 1 and 4 (each within the scatter of the next, the first and the last beyond it).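

In this assay, the change on the carbonyl carbon gives a number 40 percentage points higher from compound 3 to compound 4 (beyond the scatter) and a number 11 percentage points higher from compound 2 to compound 4 (beyond the scatter). These are the first steps shown in which the amino nitrogen and its hydrogen-bond donor leave this position, and in both the number rises, so compound 2 and compound 3 each keep a stronger effect than compound 4. No available evidence explains this rise.

The nitrogen loss and the change in ring substituents occur together in these steps, so their contributions stay unseparated. From the compounds shown here alone, how a methylene group in place of the amino nitrogen would read here remains open.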